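This account rests on a few compounds, and the source may have more. Where it says the series, first, only, none or still open, it means among the compounds named here.

Measured so far:
Compound 1 `[O-][S+]1CC(Nc2nonc2/C(=N/O)Nc2ccc(F)c(Br)c2)C1` — in an assay on HeLa cells for inhibition of Indoleamine 2,3-dioxygenase 1 (Homo sapiens), read by spectrophotometry, with a stated time of 24 h (on this read-out higher numbers stand for an effect only at larger amounts of compound and lower numbers for an effect already at smaller amounts), compound 1 gives 79 nM.
Compound 2 `N=S1(=O)CC(Nc2nonc2/C(=N/O)Nc2ccc(F)c(Br)c2)C1` — in this assay compound 2 gives 53 nM.

Compound 1 has the highest number of the two, though its step to compound 2, a 1.5-fold lower number from compound 1 to compound 2 (0.17 log units; within the scatter), lies within the scatter, so the two cannot be ranked. Compound 3 `NNS(=O)(=O)CCNc1nonc1/C(=N/O)Nc1ccc(F)c(Br)c1` has not yet been measured. It differs from compound 1 in one place: a group of 7 heavy atoms (2 carbon, 2 nitrogen, 2 oxygen, 1 sulfur; no ring) in place of a group of 5 heavy atoms (3 carbon, 1 oxygen, 1 sulfur; one four-membered non-aromatic ring with 1 hetero atom), on a nitrogen on an aromatic ring. Going by the values given here, the only measured step that bears on this is the one at the same nitrogen, a 1.5-fold lower number from compound 1 to compound 2 (0.17 log units; within the scatter), which exchanged one four-membered ring for another and produced no change beyond the scatter. Among the compounds with values here, the present change instead opens the ring into a chain, for which no measured example exists, so the expectation rests on that single small step alone. On this basis compound 3 is expected to give about 100 nM, with a range from 40 nM to 250 nM, in this assay. That corresponds to an expected step of a 1.3-fold higher number from compound 1 to compound 3 (0.10 log units; within the scatter), within the scatter.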

Compound 3, half-maximal effective concentration: > 800 nM
Compound 3 was reported as a limit (the forecaster's own chance of this, stated with the estimate: 5%); at least 8.0-fold (0.90 log units) between middle value and limit.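

Opening the four-membered ring at this nitrogen into the 2-(aminosulfamoyl)ethyl chain is the first change here to go beyond the scatter in this assay: an at least 10-fold higher number from compound 1 to compound 3 (1.00 log units; beyond the scatter), and an at least 15-fold higher number from compound 2 to compound 3 (1.17 log units; beyond the scatter). The position on a nitrogen on an aromatic ring is therefore not indifferent to what it carries, even though the exchange of one four-membered ring for the other left compound 1 and compound 2 impossible to rank. The value of compound 3 is a limit of the assay, not a number: the limit of > 800 nM in this assay, at which 1 of the 3 values shown sits.

This single change removes the ring and brings in a new chain end together, so the compounds shown cannot tell which of the two matters. A plain ethyl group, or a short chain ending in an amine or a carboxylic acid, would be needed to separate them.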